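The source may hold more compounds than are shown below. What is called first, only, known or untested is meant among the compounds shown, and "the series" means these compounds.

Three compounds have numbers in an ADME assay on the whole organism (strain 129/SvEvBrd x C57BL/6) for metabolic stability, with Mus musculus as the target; a higher number here means that the compound lasts longer, a lower number that the compound disappears faster. Compound 1 (`CC(=O)c1cccc([C@@H](O)[C@H](O)[C@H](O)CO)n1`) gives 2.1 h, compound 2 (`CC(=O)c1nc([C@@H](O)[C@H](O)[C@H](O)CO)c(C)[nH]1`) gives 6.2 h, and compound 3 (`CN(C)C(=O)c1nc([C@@H](O)[C@H](O)[C@H](O)CO)c[nH]1`) gives 4 h. Compound 3 lies within the usual scatter of both other compounds, so its half-life cannot be told apart from either. Compound 4 (`OC[C@@H](O)[C@@H](O)[C@H](O)c1c[nH]c(-c2cscn2)n1`) has 1,3-thiazol-4-yl in place of dimethylcarbamoyl on an aromatic carbon. Among the measured compounds shown here, no measured pair shows what this exchange does, so the measured half-lives are the only guide, and no shift beyond the scatter is expected. The estimated change, a 1.1-fold lower number from compound 3 to compound 4 (0.06 log units; within the scatter), stays within that scatter. For compound 4 the expected half-life is 3.5 h, with an estimated range of 1.5 h to 8 h.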

Compound 4, half-life: 4.2 h
Beside the measured number, compound 4's estimate is 1.2-fold (0.08 log units) below it; low and high end bracket the measured number.
By their numbers in this assay, from the lowest: compounds 1, 3, 4 and 2 (each within the scatter of the next, the first and the last beyond it).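

In this assay, putting 1,3-thiazol-4-yl in place of dimethylcarbamoyl on this aromatic carbon, between two ring nitrogen atoms, gives a 1.1-fold higher number from compound 3 to compound 4 (0.02 log units; within the scatter). Among the compounds shown here, this is the first direct reading at this position, and it shows that an aromatic ring and an open-chain amide group can occupy it with no half-life difference beyond the scatter. Nothing available explains this result.

This single exchange cannot show how far that tolerance extends. An amine or a carboxylic acid at the same carbon could behave differently, so the result should not be generalized to other groups.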